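Moving the Pyridine Nitrogen on a Shared Core

The compounds below may be only part of what the source reports. "The series", "measured", "known", "first", "only" and "open" are said of these compounds alone.

Measured so far:
- compound 1 `Oc1ccc(-c2cc(-c3ccccn3)cc(-c3ccccc3O)n2)cc1`: in a functional assay on HCT-15 cells (Homo sapiens) for cytotoxicity, read by CCK-8 assay (on this read-out higher numbers stand for weaker inhibition and lower numbers for stronger inhibition), compound 1 gives > 50000 nM, which is a limit of the assay, not a number.
- compound 2 `Oc1ccc(-c2cc(-c3ccccn3)cc(-c3cccc(O)c3)n2)cc1`: in this assay compound 2 gives > 50000 nM, again a limit.
- compound 3 `Oc1ccc(-c2cc(-c3ccccn3)cc(-c3ccc(O)cc3)n2)cc1`: in this assay compound 3 gives > 50000 nM, also a limit.

Compound 3 therefore stands nowhere in particular: its value is only a limit, and the two other values shown are limits as well, so no one of the three can be placed above or below another. The same holds for the steps among them. The step that the two limits leave unreadable from compound 1 to compound 2, the step that the two limits leave unreadable from compound 1 to compound 3 and the step that the two limits leave unreadable from compound 2 to compound 3 are all unreadable, because every value sits at the limit of > 50000 nM in this assay, at which 3 of the 3 values shown sit.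

Compound 4 `Oc1ccc(-c2cc(-c3cccnc3)cc(-c3ccc(O)cc3)n2)cc1` is the next compound. It differs from compound 3 by pyridin-3-yl in place of pyridin-2-yl on an aromatic carbon. Among the measured compounds shown here, no measured step speaks to this change, since all three earlier steps are hidden by the limit. What the three values do show is that the hydroxyphenyl groups could be moved around the shared core without any of the compounds reaching a readable number.

Compound 4 is estimated at 50000 nM, with a range from 15000 nM to 50000 nM. The step expected from this estimate, a number no higher from compound 3 to compound 4 (the limit leaves the size open), is most likely again hidden by the limit.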

Compound 4, half-maximal inhibitory concentration: 840 nM
Estimate against measurement, compound 4: 60-fold (1.77 log units) above; the measured number lies below the stated range.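

In this assay, among the compounds shown here, placing pyridin-3-yl instead of pyridin-2-yl on this aromatic carbon, opposite the ring nitrogen of the shared core, gives an at least 59-fold lower number from compound 3 to compound 4 (1.77 log units; beyond the scatter), the first step that can be read. Moving the hydroxyl group around the hydroxyphenyl rings of compound 1, compound 2 and compound 3 produced no readable number, whereas this change shows that the place of the nitrogen in this one ring can produce one, even though the two groups have the same atoms and the same counts of hydrogen-bond donors and acceptors. Compound 3 gives > 50000 nM, which is a limit of the assay, so the step fixes only a smallest size and not a true one.

From the compounds shown here alone, how a pyridin-4-yl group or a plain phenyl group would behave at this position remains open. Also open, going by these compounds, are whether pyridin-3-yl would give a readable number alongside the 2-hydroxyphenyl group of compound 1 or the 3-hydroxyphenyl group of compound 2, and what lies behind the step, for which the data offer no cause.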